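Swapping Thiophene for Furan on a Shared Core

The source may hold more compounds than are shown below. What is called first, only, known or untested is meant among the compounds shown, and "the series" means these compounds.

Compound 1 `Cc1cccc(Nc2nccc(-c3ccsc3)n2)c1`: 3800 nM
Compound 2 `Cc1ccsc1-c1ccnc(Nc2ccc(N(C)C)cc2)n1`: 1800 nM
Compound 3 `CCc1cccc(Nc2nccc(-c3ccsc3)n2)c1`: 1100 nM

In a functional assay for inhibition, with Homo sapiens as the target (a lower number here means a stronger inhibitor, a higher number a weaker inhibitor), compound 3 stands at the low end of the numbers shown. Going by the values given here, compound 2 lies within the scatter of it, so the two cannot be told apart, while compound 1 sits beyond the scatter, as the one single-place step shows: a 3.5-fold lower number from compound 1 to compound 3 (0.54 log units; beyond the scatter). Compound 4 `CCc1cccc(Nc2nccc(-c3ccco3)n2)c1` differs from compound 3 in one place: furan-2-yl in place of thiophen-3-yl on an aromatic carbon. Among the compounds with values here, no measured step bears on this change; the only measured step, from compound 1 to compound 3, concerns a different part of the molecule. Without a precedent, no direction can be expected for compound 4 beyond a modest shift either way. The step is expected to be a 1.4-fold higher number from compound 3 to compound 4 (0.13 log units; within the scatter). Compound 4 is estimated at 1500 nM, within a range from 500 nM to 4500 nM.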

Compound 4, half-maximal inhibitory concentration: 9700 nM
For compound 4 the middle estimate is 6.5-fold (0.81 log units) below the measured one; measured number above the stated range.
By their numbers in this assay, from the lowest: compounds 3 and 2 (each within the scatter of the next); then compound 1; then compound 4.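

Swapping the ring on this aromatic carbon matters in this assay: the step shows an 8.8-fold higher number from compound 3 to compound 4 (0.95 log units; beyond the scatter), even though thiophen-3-yl and furan-2-yl have the same counts of heavy atoms and hydrogen-bond acceptors. Matching counts therefore do not make these two rings interchangeable here. No measurement at hand explains the difference.

This change alters both the hetero atom, sulfur to oxygen, and the ring's point of attachment, so the step cannot separate the two. Furan-3-yl on the same core would pull them apart, and phenyl would show what a ring without a hetero atom gives.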